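The source may hold more compounds than are shown below. What is called first, only, known or untested is meant among the compounds shown, and "the series" means these compounds.

Measured compounds:
Compound 1 `CC(C)CCN1C(=O)C(C2=NS(=O)(=O)c3cc(NS(C)(=O)=O)ccc3N2)=C(O)C2CCCC21` gives > 1000 nM in an ADME assay on Huh-7 cells (Homo sapiens) for cytotoxicity, with a stated time of 72 h (on this read-out higher numbers stand for lower toxicity in this test and lower numbers for higher toxicity in this test), a limit of the assay rather than a number.
Compound 2 `CN1C(=O)C(C2=NS(=O)(=O)c3cc(NS(C)(=O)=O)ccc3N2)=C(O)C2CCCC21` has "not determined" (no result reported) in this assay.
Compound 3 `CS(=O)(=O)Nc1ccc2c(c1)S(=O)(=O)N=C(C1=C(O)C3CCCC3N(C3CCCC3)C1=O)N2` has "not determined" (no result reported) in this assay.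

Compound 3 therefore stands without a number of its own in this assay; of the other two entries, one is a limit of the assay, at which one of the three values sits (the limit of > 1000 nM in this assay, at which 1 of the 3 values shown sits), and one is without a result. Compound 4 `CCN1C(=O)C(C2=NS(=O)(=O)c3cc(NS(C)(=O)=O)ccc3N2)=C(O)C2CCCC21` differs from compound 3 by ethyl in place of cyclopentyl on an amide-type nitrogen in a ring. Among the compounds with values here, no measured step between two compounds exists in this assay, so no size can be drawn from it; with the one value at the limit, no change beyond the scatter is expected in this assay. Compound 4 is estimated at 1000 nM, with a range from 500 nM to 3000 nM, most likely reported again as a limit.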

Compound 4, half-maximal cytotoxic concentration: > 33000 nM
Compound 4: a limit, no number; the forecaster's own chance of this, stated with the estimate: 80%; at least 33-fold (1.51 log units) between middle value and limit.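

In this assay compound 1 gives > 1000 nM, a limit of the assay and not a number. Compound 4 gives > 33000 nM, also a limit. Within the data shown here, no step between compound 1 and compound 4 can be read from these two limits. The compounds shown leave open at what concentration either compound reaches its half-maximal cytotoxic effect in this assay.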